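Nitro to Methyl Within a Series at the Limit

The source may report more compounds than this note shows. Statements on the series, on what has been measured and on what is new or still open speak of the compounds shown alone.

Three measured compounds share one core. Compound 1 `Cc1ccc(-n2cc(CNC(=O)c3cccc4c3cnn4C(C)C)nn2)cc1C` carries a 3,4-dimethylphenyl group on an aromatic nitrogen. In a functional assay on MCF7 cells (Homo sapiens) for inhibition, read by MTT assay, with a stated time of 72 h (on this read-out lower numbers stand for stronger inhibition and higher numbers for weaker inhibition), compound 1 reaches only > 40000 nM, which is a limit of the assay and not a number. Compound 2 `CC(C)n1ncc2c(C(=O)NCc3cn(-c4ccc(I)cc4)nn3)cccc21` bears 4-iodophenyl in place of that group. In this assay compound 2 likewise stops at the limit > 40000 nM. Compound 3 `CC(C)n1ncc2c(C(=O)NCc3cn(-c4ccc([N+](=O)[O-])cc4)nn3)cccc21` carries 4-nitrophenyl. In this assay compound 3 also stops at the limit > 40000 nM. Because of the limit of > 40000 nM in this assay, at which 3 of the 3 values shown sit, the three steps a step that the two limits leave unreadable from compound 1 to compound 2, a step that the two limits leave unreadable from compound 1 to compound 3 and a step that the two limits leave unreadable from compound 2 to compound 3 cannot be read in size, so compound 3 stands only as a limit, alongside two further limits.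

Compound 4 `Cc1ccc(-n2cc(CNC(=O)c3cccc4c3cnn4C(C)C)nn2)cc1` differs from compound 3 by methyl in place of nitro on an aromatic carbon. For the measured compounds named here, no measured step bears on this change in a readable way, since every measured step is hidden behind the same limit. The expected step is therefore a step that the limit leaves unreadable from compound 3 to compound 4, meaning no change beyond the scatter is expected. Compound 4 is expected to give an estimated 60000 nM, within 20000 nM to 200000 nM, most likely reported again as a limit rather than a number.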

Compound 4, half-maximal inhibitory concentration: > 40000 nM
Compound 4: only a limit was reported; the forecaster's own chance of this, stated with the estimate: 80%; the middle value does not contradict the limit.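

In this assay compound 4 gives > 40000 nM, which is a limit of the assay and not a number. The steps from compound 1, compound 2 and compound 3 to compound 4 cannot be read in size, because every value shown is a limit: the limit of > 40000 nM in this assay, at which 4 of the 4 values shown sit.

The compounds shown leave open whether swapping these phenyl groups changes inhibition at all.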